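Extending the piperidine chain from compound 1

This account rests on a few compounds, and the source may have more. Where it says the series, first, only, none or still open, it means among the compounds named here.

Measured in a functional assay on BCG823 cells (Homo sapiens) for antiproliferative activity, read by MTT assay, with a stated time of 48 h; a lower number here means a stronger inhibitor, a higher number a weaker inhibitor:
- compound 1 `COc1c(OCCCN2CCCCC2)cc2oc(-c3ccccc3)cc(=O)c2c1O`: 9700 nM
- compound 2 `COc1c(OCCCCN2CCCC2)cc2oc(-c3ccccc3)cc(=O)c2c1O`: 9500 nM

Compound 1, at 9700 nM, cannot be separated from compound 2, at 9500 nM, as the two lie within the scatter of each other. Compound 3 `COc1c(OCCCCN2CCCCC2)cc2oc(-c3ccccc3)cc(=O)c2c1O` remains unmeasured. Its structural change from compound 1 is (piperidin-1-yl)methyl in place of piperidin-1-yl on a saturated chain carbon, three bonds along the chain from an oxygen on an aromatic ring. Among the compounds with values here, only one measured step bears on this change: a 1.0-fold lower number from compound 1 to compound 2 (0.01 log units; within the scatter). That step puts (pyrrolidin-1-yl)methyl at the same place on the chain and leaves the number within the scatter. It differs from the present change in the ring it brings in, so it is only partial evidence. No step beyond the scatter is therefore expected in this assay, and no direction can be assigned with confidence. The expected step is a 1.1-fold lower number from compound 1 to compound 3 (0.04 log units; within the scatter). For compound 3, the estimated value is 8800 nM, with an expected range of 4200 nM to 18000 nM.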

Compound 3, half-maximal inhibitory concentration: 6600 nM
Beside the measured number, compound 3's estimate is 1.3-fold (0.12 log units) above it; the measured number falls inside the stated range.
By their numbers in this assay, from the lowest: compounds 3, 2 and 1 (each within the scatter of the next).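

In this assay, going from 3-(piperidin-1-yl)propyl to 4-(piperidin-1-yl)butyl with the piperidine ring kept gives a 1.5-fold lower number from compound 1 to compound 3 (0.17 log units; within the scatter), so this one-carbon extension of the chain, previously seen only together with a change of ring, does not by itself shift the number beyond the scatter. The ring change can now be read alone at the longer chain: piperidin-1-yl in place of pyrrolidin-1-yl gives a 1.4-fold lower number from compound 2 to compound 3 (0.16 log units; within the scatter), so the two rings cannot be told apart at this position. No measured evidence bears on why the numbers sit where they do.

On these data alone, whether a shorter 2-(piperidin-1-yl)ethyl chain or a chain longer than butyl would give a step beyond the scatter remains open. As far as these compounds go, it is equally open whether a morpholine ring in place of piperidine would do so.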